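The source may report more compounds than this note shows. Statements on the series, on what has been measured and on what is new or still open speak of the compounds shown alone.

Working notes on the series. Compound 1 (`Clc1ccc2[nH]c(-c3cn(-c4ccccc4)nc3-c3ccccc3)nc2c1`), compound 2 (`Brc1ccc2[nH]c(-c3cn(-c4ccccc4)nc3-c3ccccc3)nc2c1`) and compound 3 (`COc1ccc2[nH]c(-c3cn(-c4ccccc4)nc3-c3ccccc3)nc2c1`) share one core and differ in a single group on an aromatic carbon. In an ADME assay on HaCaT cells (Homo sapiens) for cytotoxicity, read by MTT assay, with a stated time of 48 h (on this read-out higher numbers stand for weaker inhibition and lower numbers for stronger inhibition), compound 1 gives > 50000 nM as a limit of the assay, not as a number. Compound 2 gives > 50000 nM as a limit too. Compound 3 gives > 50000 nM as a limit as well. Compound 3 therefore has no number of its own, and the measured series stands at the limit of > 50000 nM in this assay, at which 3 of the 3 values shown sit, with no ranking.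

Compound 4 (`O=C(OCc1ccccc1)c1ccc2[nH]c(-c3cn(-c4ccccc4)nc3-c3ccccc3)nc2c1`) carries benzyloxycarbonyl in place of methoxy on an aromatic carbon. The entering group brings a six-membered aromatic ring of carbon only.

Three measured swaps bear on this change: a step that the two limits leave unreadable from compound 1 to compound 2 and a step that the two limits leave unreadable from compound 1 to compound 3 and a step that the two limits leave unreadable from compound 2 to compound 3 give no size to carry over. The expectation rests on compound 3 with its limit of > 50000 nM as the starting point. No step beyond the scatter is expected in this assay and a number no higher from compound 3 to compound 4 (the limit leaves the size open) is the estimated step. A further limit is the most likely report, and any number that appears is expected on the side of stronger inhibition. For compound 4 the estimate is 50000 nM with an expected range of 20000 nM to 100000 nM in this read-out.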

Compound 4, half-maximal inhibitory concentration: > 50000 nM
Compound 4 gave a limit, no number; the forecaster's own chance of this, stated with the estimate: 75%; the middle value sits exactly at the limit.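

No step can be read between compound 4 and compound 1, compound 2 or compound 3 in this assay, as all four compounds stand at a limit and not at a number: the limit of > 50000 nM in this assay, at which 4 of the 4 values shown sit.

The compounds shown leave open what number any of the four would have on this read-out, and whether exchanging the group on the aromatic carbon changes it at all.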